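Removing the side chain from compound 2

The compounds below may be only part of what the source reports. "The series", "measured", "known", "first", "only" and "open" are said of these compounds alone.

Compound 1 `CN1CCN(CCCn2c3c(c4ccccc42)C(=O)c2c[n+]([O-])c4ccccc4c2C3=O)CC1`: 560 nM
Compound 2 `CN(C)CCCCn1c2c(c3ccccc31)C(=O)c1c[n+]([O-])c3ccccc3c1C2=O`: 250 nM

Both numbers come from a functional assay on SH-SY5Y cells (Homo sapiens) for cytotoxicity, read by MTT assay, with a stated time of 72 h; a lower number here means a stronger inhibitor, a higher number a weaker inhibitor. Of the two, compound 2 stands lowest at 250 nM, which makes it the stronger inhibitor.

The next compound to be measured, compound 3 `O=C1c2c[n+]([O-])c3ccccc3c2C(=O)c2[nH]c3ccccc3c21`, keeps the shared core but loses the whole side chain: hydrogen in place of 4-(dimethylamino)butyl on an aromatic nitrogen. In plain words, this puts hydrogen in place of 4-(dimethylamino)butyl on an aromatic nitrogen.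

For the measured compounds named here, only one measured step offers any guidance: a 2.2-fold lower number from compound 1 to compound 2 (0.35 log units; beyond the scatter). That modest step exchanged a group on the chain, whereas in compound 3 no chain remains at all. Going by the values given here, no measured compound shows what full removal does, so the guidance is weak. A step larger than that one is expected in this assay, more likely toward a higher number, although the direction remains uncertain. The expected change is a 3.6-fold higher number from compound 2 to compound 3 (0.56 log units; beyond the scatter). For compound 3 the estimated value is 900 nM, with an expected range of 150 nM to 5000 nM.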

Compound 3, half-maximal inhibitory concentration: 1380 nM
Estimate against measurement, compound 3: 1.5-fold (0.19 log units) below; measured number inside the range.
By their numbers in this assay, from the lowest: compound 2; then compound 1; then compound 3.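

In this assay the aromatic nitrogen carrying no chain at all can now be compared with the same nitrogen carrying a chain, and losing the 4-(dimethylamino)butyl chain gives a 5.5-fold higher number from compound 2 to compound 3 (0.74 log units; beyond the scatter) while losing the 3-(4-methylpiperazin-1-yl)propyl chain gives a 2.5-fold higher number from compound 1 to compound 3 (0.39 log units; beyond the scatter). Both steps point the same way: each of the two chains goes with a lower number than the bare core, yet the core alone still gives a measurable number, with compound 3 at 1380 nM in the same test, so a chain on this nitrogen is not needed for a reading. Nothing available bears on the reason for these steps.

From the compounds shown here alone, compound 1 and compound 2 differ in both the length of the chain and the amine at its end, so the share of each in the lower numbers remains unknown. A plain butyl chain with no amine, a 3-(dimethylamino)propyl chain or a chain ending in a carboxylic acid would help to separate the contribution of the chain itself from that of the amine.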